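From 4-methoxyphenyl to 1H-indol-7-yl on a shared core

A few compounds are considered here, and "the series" means these few. Any claim that something is new, unique, unknown or untested is made for them only; others in the source may bear on it.

Values in a functional assay on HepG2 cells (Homo sapiens) for cytotoxicity, read by spectrophotometry, with a stated time of 72 h; a lower number here means a stronger inhibitor, a higher number a weaker inhibitor:
Compound 1 `COc1ccc(-c2cccc(=O)n2-c2cc(OC)c(OC)c(OC)c2)cc1`: < 10 nM
Compound 2 `COc1ccc(-c2cccc(=O)n2-c2cc(OC)c(OC)c(OC)c2)cc1C`: 129 nM
Compound 3 `COc1cc(-n2c(-c3cccc(O)c3)cccc2=O)cc(OC)c1OC`: 34 nM

Compound 1 gives < 10 nM, which is a limit of the assay and not a number. Compound 4 `COc1cc(-n2c(-c3cccc4cc[nH]c34)cccc2=O)cc(OC)c1OC` carries 1H-indol-7-yl in place of 4-methoxyphenyl on an aromatic carbon. Two measured changes to that same group both raise the number: an at least 12-fold higher number from compound 1 to compound 2 (1.11 log units; beyond the scatter), and an at least 3.4-fold higher number from compound 1 to compound 3 (0.53 log units; beyond the scatter). The second of these also replaces the whole group, so a modest to large rise, towards weaker inhibition, is expected in this assay. The expected change is an at least 4.0-fold higher number from compound 1 to compound 4 (0.60 log units; beyond the scatter). For compound 4 the estimate is 40 nM, with an expected range from 8 nM to 200 nM.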

Compound 4, half-maximal inhibitory concentration: 2400 nM
Estimate against measurement, compound 4: 60-fold (1.78 log units) below, outside the stated range (above it).
By their numbers in this assay, from the lowest: compound 3; then compound 2; then compound 4. At a limit, below all of these: compound 1.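

In this assay, 1H-indol-7-yl at this position gives a 71-fold higher number from compound 3 to compound 4 (1.85 log units; beyond the scatter) and a 19-fold higher number from compound 2 to compound 4 (1.27 log units; beyond the scatter), so replacing the single six-membered ring here can cost far more than compounds 2 and 3 suggested. The step from compound 1 is an at least 240-fold higher number from compound 1 to compound 4 (2.38 log units; beyond the scatter). That step starts from a limit of the assay, so its full size cannot be read: the limit of < 10 nM in this assay, at which 1 of the 4 values shown sits.

On these data alone, whether the loss goes with the added five-membered ring or with the way the group is attached stays open. A 3-aminophenyl or 1H-indol-5-yl group at this place could help separate the two.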